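The source may report more compounds than this note shows. Statements on the series, on what has been measured and on what is new or still open speak of the compounds shown alone.

Among the compounds with values here, in a functional assay for inhibition, tested at 100 uM (on this read-out higher numbers stand for more inhibition at the one concentration tested (going by the name of the read-out) and lower numbers for less inhibition), compound 1 `O=S(=O)(/C=C/S(=O)(=O)c1ccccc1)CC1=NCCS1` gives 30.4%, the lower of the two numbers measured so far. Within the data shown here, compound 2 `O=S(=O)(/C=C/S(=O)(=O)c1ccccc1)CC1=NCCO1` gives 82.1%, and the only measured step, a number 51.7 percentage points higher from compound 1 to compound 2 (beyond the scatter), exchanges the five-membered ring on the saturated chain carbon bound to a sulfonyl sulfur. Compound 3 `O=S(=O)(/C=C/S(=O)(=O)c1ccc(Cl)cc1)CC1=NCCS1` differs from compound 1 elsewhere: chloro in place of hydrogen on an aromatic carbon. Among the measured compounds shown here, no measured step touches the aromatic ring, so nothing measured bears on this change. The step expected here, a number 2.6 percentage points higher from compound 1 to compound 3 (within the scatter), is therefore one within the scatter. Compound 3 is estimated at 33%, with a range from 15% to 55%.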

Compound 3, a percentage reported as inhibition, at one concentration (the size of the read-out at that concentration, not a potency): 32.3%
Compound 3: the middle estimate sits 0.7 percentage points above what was measured; measured number inside the range.
By their numbers in this assay, from the lowest: compounds 1 and 3 (each within the scatter of the next); then compound 2.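

In this assay, chloro on the aromatic carbon para to a large group gives a number 1.9 percentage points higher from compound 1 to compound 3 (within the scatter), so this phenyl to 4-chlorophenyl change leaves the number within the scatter on the core of compound 1. This is the only step shown at the aromatic ring, and it is far smaller than a number 51.7 percentage points higher from compound 1 to compound 2 (beyond the scatter), the exchange of the five-membered ring. Nothing available explains why the chloro step is so small.

The chloro step is shown only on the core of compound 1, so its size on the core of compound 2 remains open. Also open, going by these compounds, is what a methoxy group, an amine or a carboxylic acid would do at this aromatic carbon.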